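Methoxy at the Para Position of an Inactive Thioether

The source may report more compounds than this note shows. Statements on the series, on what has been measured and on what is new or still open speak of the compounds shown alone.

Measured compounds in an ADME assay on isolated protein for inhibition of Amine oxidase [flavin-containing] B (Homo sapiens); a higher number here means a weaker inhibitor, a lower number a stronger inhibitor:
Compound 1 `C#CCNC1CCc2c(SCc3ccc(Br)cc3)cccc21`: 488 nM
Compound 2 `C#CCNC1CCc2c(SCc3ccc(C(F)(F)F)cc3)cccc21`: 930 nM
Compound 3 `C#CCNC1CCc2c(SCc3ccccc3)cccc21`: "not active" (no number reported), with no number given

Compound 3 is the unsubstituted member of this small set. Its half-maximal inhibitory concentration was not reported as a number; compound 3 was simply recorded as "not active" (no number reported). Compound 1, which carries bromo, gives 488 nM, and compound 2, which carries trifluoromethyl, gives 930 nM, so both substituted compounds have a measurable number where compound 3 has none.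

Compound 4 `C#CCNC1CCc2c(SCc3ccc(OC)cc3)cccc21` is the next step from compound 3: methoxy in place of hydrogen on an aromatic carbon. Among the compounds with values here, no measured step covers the move from hydrogen to methoxy. Within the data shown here, the one step available, a 1.9-fold higher number from compound 1 to compound 2 (0.28 log units; within the scatter), lies between two substituted compounds and shows that two different groups at this position land close to each other. That step does not bear directly on going from no group to a group, so the direction is taken only from compound 3 having no number while compound 1 and compound 2 do.

Compound 4 is therefore expected to show a measurable number in this assay, estimated at 1500 nM, with a range from 400 nM to 8000 nM, while a report of no activity remains possible.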

Compound 4, half-maximal inhibitory concentration: 3960 nM
Beside the measured number, compound 4's estimate is 2.6-fold (0.42 log units) below it, within the range that was stated.
By their numbers in this assay, from the lowest: compounds 1 and 2 (each within the scatter of the next); then compound 4.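

In this assay, methoxy on this aromatic carbon, para to a large group, yields a number, so compound 4 joins compound 1 and compound 2 as a substituted compound with a value where compound 3 has none; the step from hydrogen to methoxy itself cannot be read as a size. The earlier pair could not show that the choice of group changes the number, since bromo and trifluoromethyl lay within the scatter of each other, but methoxy separates clearly: there is a 4.3-fold higher number from compound 2 to compound 4 (0.63 log units; beyond the scatter) and also an 8.1-fold higher number from compound 1 to compound 4 (0.91 log units; beyond the scatter), and both steps lie beyond the scatter. No measurement is available here to explain why methoxy gives the highest number of the three.

The compounds shown leave open where a chloro, a hydroxyl or an amine on this same aromatic carbon would fall relative to these three values. They also leave open whether a longer chain such as ethoxy in place of methoxy would move the number further up or bring it back down.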